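The source may report more compounds than this note shows. Statements on the series, on what has been measured and on what is new or still open speak of the compounds shown alone.

Working notes on the series. Compound 1 `COC(=O)C(C)c1ccc(-c2ccc(C(=O)/C=C/c3ccc(CN4CCCCC4)c(O)c3)cc2)c(F)c1` gives 430 nM in an assay on isolated protein for inhibition of Amine oxidase [flavin-containing] B (Homo sapiens), read by fluorescence, with a stated time of 30 min; a lower number here means a stronger inhibitor, a higher number a weaker inhibitor. Among the measured compounds shown here, compound 2 `COC(=O)C(C)c1ccc(-c2ccc(C(=O)/C=C/c3ccc(CN4CCN(C)CC4)c(O)c3)cc2)c(F)c1` gives 430 nM in this assay, and the one measured step, no change at the digits printed from compound 1 to compound 2 (within the scatter), is flat within the scatter: the swap of 4-methylpiperazin-1-yl for piperidin-1-yl on a saturated chain carbon bound to an aromatic carbon leaves the value where it was. Compound 2 therefore stands level with compound 1 at the digits shown.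

Compound 3 `CCN1CCN(Cc2ccc(/C=C/C(=O)c3ccc(-c4ccc(C(C)C(=O)OC)cc4F)cc3)cc2O)CC1` is not yet measured in this assay. Its difference from compound 2 is methyl in place of hydrogen on a saturated chain carbon bound to an amine nitrogen in a ring, a small enlargement of the same basic ring substituent whose exchange in the step from compound 1 to compound 2 produced no shift. For the measured compounds named here, that step is the only one bearing on this change, and it was flat, so no step beyond the scatter is expected for this assay, in either direction.

Compound 3 is therefore expected to give about 430 nM in this assay, within 200 nM to 900 nM, which means an expected step of no change at the digits printed from compound 2 to compound 3 (within the scatter).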

Compound 3, half-maximal inhibitory concentration: 430 nM
Compound 3: middle estimate and measured number agree at the digits printed, and the stated range covers the measured number.
By their numbers in this assay, from the lowest: compounds 1, 2 and 3 (each within the scatter of the next).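

In this assay the enlargement of methyl to ethyl on the 4-methylpiperazin-1-yl group gives no change at the digits printed from compound 2 to compound 3 (within the scatter) and adds a second flat exchange to the one seen earlier. The direct comparison of 4-ethylpiperazin-1-yl with piperidin-1-yl also reads no change at the digits printed from compound 1 to compound 3 (within the scatter) and so all three groups on this saturated chain carbon bound to an aromatic carbon cannot be told apart in this assay. Nothing at hand offers an explanation for this flat result.

From the compounds shown here alone, how far this tolerance extends remains open: a longer chain such as propyl or a hydroxyethyl chain in place of the ethyl could behave differently. Also open, going by these compounds, is whether the flat reading holds with a carboxylic acid in place of the methyl ester on the shared core.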